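The source may report more compounds than this note shows. Statements on the series, on what has been measured and on what is new or still open speak of the compounds shown alone.

Working notes on the series.

Of the compounds shown here, two carry numbers so far. Compound 1 `COc1ccc2ncc(S(=O)(=O)c3ccc(C)c(Cl)c3)c(N3CCC(C)CC3)c2c1` and compound 2 `CC1CCN(c2c(S(=O)(=O)c3ccc(F)c(F)c3)cnc3ccc(F)cc23)CC1` share one core and differ in the groups hung on it. In an assay on isolated protein for displacement of a labelled ligand from metabotropic glutamate receptor 5 (Homo sapiens), with a stated time of 60 min, tested at 1 uM (on this read-out higher numbers stand for more inhibition at the one concentration tested (going by the name of the read-out) and lower numbers for less inhibition), compound 1 gives 85%. In this assay compound 2 gives 82%; compound 2 thus stands with the lowest of the two numbers, the nearest being compound 1, whose number is higher by an amount that lies within the usual scatter, so the two values cannot be ordered.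

The next compound, compound 3 `Cc1ccc(S(=O)(=O)c2cnc3ccc(F)cc3c2N2CCC(C)CC2)cc1Cl`, is not yet measured in this assay. Relative to compound 2 it carries 3-chloro-4-methylphenyl in place of 3,4-difluorophenyl on a sulfonyl sulfur. Within the data shown here, no measured pair in the set isolates this exact change, so its effect is not known from the data. The entering group is the same one that compound 1 carries on its sulfonyl sulfur, and compound 1 gives 85% in this assay, which leaves no room for a shift beyond the scatter at the one concentration tested.

For compound 3 the step from compound 2 is expected to be a number 3 percentage points higher from compound 2 to compound 3 (within the scatter), not beyond the scatter in either direction. Compound 3 is therefore estimated at 85% in this assay, with a range from 72% to 94%.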

Compound 3, a percentage reported as inhibition, at one concentration (the size of the read-out at that concentration, not a potency): 91%
The estimate for compound 3 lay 6 percentage points below the measured number; measured number inside the range.
By their numbers in this assay, from the lowest: compounds 2, 1 and 3 (each within the scatter of the next).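

In this assay the exchange of 3,4-difluorophenyl for 3-chloro-4-methylphenyl on a sulfonyl sulfur now has its own measured pair, and the step is a number 9 percentage points higher from compound 2 to compound 3 (within the scatter) on the shared core, so at the one concentration tested the two groups cannot be told apart at this position. Among these compounds, a second place is also isolated for the first time, fluoro in place of methoxy on an aromatic carbon, where the step is a number 6 percentage points higher from compound 1 to compound 3 (within the scatter) and this change likewise cannot be resolved on this read-out. No supporting measurement bears on either step, so neither can be explained from the data in hand.

Among the compounds shown here, whether a carboxylic acid, an amine or a longer chain in place of the substituted phenyl on the sulfonyl sulfur would give a step beyond the scatter remains open, since only two substituted phenyl groups appear at that position. Each number is also a response at a single concentration rather than a potency, so any ordering of these three compounds would need a full concentration series.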